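Carboxymethoxy in place of 2-carboxyethyl on the shared core

The source may report more compounds than this note shows. Statements on the series, on what has been measured and on what is new or still open speak of the compounds shown alone.

All three measured compounds share one core, seen in compound 1 `Cc1cc(OCc2c(-c3c(Cl)cccc3Cl)noc2C(C)C)ncc1[N+](=O)[O-]`. In a functional assay on HEK293 cells for agonist activity at Bile acid receptor (Homo sapiens) (a lower number here means a smaller maximal response, a higher number a larger maximal response), compound 1 gives 58%. Compound 2 `Cc1cc(C(F)(F)F)cc(OCc2c(-c3c(Cl)cccc3Cl)noc2C(C)C)n1` carries a trifluoromethyl group instead of the nitro group, and in this assay compound 2 is reported as "not active" (no number reported), so no number stands for it. Compound 3 `CC(C)c1onc(-c2c(Cl)cccc2Cl)c1COc1ccc(N(C)Cc2ccc(CCC(=O)O)cc2)c(C(F)(F)F)n1` adds a long side arm that ends in a 2-carboxyethyl group, and in this assay compound 3 gives 55%. Among the two numbers known, compound 3 and compound 1 lie within the usual scatter of each other, so nothing separates them; the only other entry, compound 2, gave no number at all.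

Compound 4 `CC(C)c1onc(-c2c(Cl)cccc2Cl)c1COc1ccc(N(C)Cc2ccc(OCC(=O)O)cc2)c(C(F)(F)F)n1` is compound 3 with one change at the far end of the side arm: carboxymethoxy in place of 2-carboxyethyl on an aromatic carbon. Among the measured compounds shown here, no pair of measured compounds differs in this way, so there is no measured step to lean on. The change is small in size, and the expectation is a step from compound 3 to compound 4 of a number 5 percentage points lower from compound 3 to compound 4 (within the scatter), essentially none beyond the scatter. Compound 4 is therefore expected to give about 50% in this assay, with a plausible range from 30% to 70%.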

Compound 4, largest response reached (reported as efficacy), in percent of the reference or control that the assay uses: 69%
Estimate against measurement, compound 4: 19 percentage points below, within the range that was stated.
By their numbers in this assay, from the lowest: compounds 3 and 1 (each within the scatter of the next); then compound 4.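

In this assay, the far end of the side arm turns out to matter: carboxymethoxy in place of 2-carboxyethyl, on an aromatic carbon para to a large group, gives a number 14 percentage points higher from compound 3 to compound 4 (beyond the scatter). Among the compounds shown here, this is the first comparison here between compounds that differ in one place only, and the change is a subtle one: both groups hold 5 heavy atoms and end in the same acid, yet carboxymethoxy has 3 oxygen atoms and 2 hydrogen-bond acceptors where 2-carboxyethyl has 2 oxygen atoms and 1 hydrogen-bond acceptor. So even an exchange that leaves the heavy-atom count untouched can shift the maximal response at this position, though no measurement at hand explains the shift.

On these data alone, what remains open is how other groups at this position would read, such as a longer chain like 3-carboxypropyl, or a primary amide or a tetrazole in place of the carboxylic acid. A single step also cannot tell whether the same exchange would raise the response on a compound that differs elsewhere in the molecule.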